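The source may hold more compounds than are shown below. What is called first, only, known or untested is meant among the compounds shown, and "the series" means these compounds.

Working notes on the series.

The compounds share a core built around a sulfonamide, and all have been examined in an assay on cells for inhibition of HSP60/HSP10 (Homo sapiens), with a stated time of 60 min; a lower number here means a stronger inhibitor, a higher number a weaker inhibitor. Compound 1 `O=S(=O)(Nc1ccc2oc(-c3ccccc3)nc2c1)c1cccc(F)c1` carries a 3-fluorophenyl on the sulfonyl sulfur. In this assay compound 1 returns > 100000 nM, which is a limit of the assay and not a number. Compound 2 `O=[N+]([O-])c1cc(S(=O)(=O)Nc2ccc(-c3nc4ccccc4o3)cc2)ccc1Cl` in this assay gives 17000 nM. Compound 3 `O=S(=O)(Nc1ccc(-c2nc3ccccc3o2)cc1)c1cccc(C(F)(F)F)c1` in this assay gives 57000 nM. Among the compounds with values here, no two of the measured compounds differ in one place only, so no single measured step is available to set the size of a substituent change. Of what is measured, compound 1 stands at the limit of > 100000 nM in this assay, at which 1 of the 3 values shown sits, while compound 2 and compound 3 give numbers.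

Compound 4 `CCc1ccc(S(=O)(=O)Nc2ccc3oc(-c4ccccc4)nc3c2)cc1` is not yet measured. It differs from compound 1 by 4-ethylphenyl in place of 3-fluorophenyl on a sulfonyl sulfur. Within the data shown here, the data hold no measured step of this kind, so the direction and size of the step from compound 1 to compound 4 can only be guessed; a move of the order of the scatter or somewhat larger, towards a lower number, is expected, as an at least 1.2-fold lower number from compound 1 to compound 4 (0.09 log units; that floor lies within the scatter). Compound 4 in this assay is expected at 80000 nM, with a range from 25000 nM to 250000 nM, and a fair chance that this assay again returns only a limit.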

Compound 4, half-maximal inhibitory concentration: > 100000 nM
Compound 4: no number, only a limit (the forecaster's own chance of this, stated with the estimate: 55%); middle value at least 1.2-fold (0.09 log units) away from the limit.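

In this assay compound 4 returns > 100000 nM, a limit of the assay and not a number. Compound 1 stands at a limit as well, so no step between compound 1 and compound 4 can be read: the limit of > 100000 nM in this assay, at which 2 of the 4 values shown sit.

The compounds shown leave open whether 4-ethylphenyl in place of 3-fluorophenyl on a sulfonyl sulfur changes the inhibition at all.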